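This account rests on a few compounds, and the source may have more. Where it says the series, first, only, none or still open, it means among the compounds named here.

In a functional assay on MV4-11 cells (Homo sapiens) for cytotoxicity, read by colorimetric assay and MTT assay, with a stated time of 3 days, tested at 1 uM (on this read-out lower numbers stand for a stronger effect and higher numbers for a weaker effect at the one concentration tested), the three measured compounds read as follows:

compound 1 `O=C1COc2ccc(-c3[nH]c(-c4ccc(C(F)(F)F)cc4)nc3-c3ccccc3)cc2N1`: 111%
compound 2 `O=C1COc2ccc(-c3[nH]c(-c4ccc(F)cc4)nc3-c3ccccc3)cc2N1`: 108%
compound 3 `O=C1COc2ccc(-c3nn(-c4ccc(Br)cc4)cc3-c3ccccc3)cc2N1`: 108%

Compound 3 stands level with compound 2 at the digits shown, and the two together hold the lowest of the three numbers; its distance to compound 1 is small and lies within the scatter. For the measured compounds named here, the single measured step, a number 3 percentage points lower from compound 1 to compound 2 (within the scatter), puts fluoro in place of trifluoromethyl on an aromatic carbon and stays within the scatter, so nothing among the measured pairs has moved this read-out.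

Compound 4 `COc1ccc(-n2cc(-c3ccccc3)c(-c3ccc4c(c3)NC(=O)CO4)n2)cc1` differs from compound 3 by methoxy in place of bromo on an aromatic carbon. Going by the values given here, no measured step involves a methoxy group, so the only guidance is the general flatness of the three numbers and the unchanged step from compound 1 to compound 2. Compound 4 is therefore expected to show a step of a number 1 percentage points lower from compound 3 to compound 4 (within the scatter), that is, nothing beyond the scatter. The estimate for compound 4 in this assay is 107%, within a range from 95% to 119%.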

Compound 4, a percentage reported as activity, at one concentration (the size of the read-out at that concentration, not a potency): 106%
Compound 4: the middle estimate sits 1 percentage points above what was measured; the measured number falls inside the stated range.
By their numbers in this assay, from the lowest: compounds 4, 2, 3 and 1 (each within the scatter of the next).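

In this assay, putting methoxy in place of bromo, the change from 4-bromophenyl to 4-methoxyphenyl, gives a number 2 percentage points lower from compound 3 to compound 4 (within the scatter). For the compounds shown here, this is the first measured step on this ring of the compound 3 series, and it shows that swapping a single halogen atom for a group that brings one hydrogen-bond acceptor, on an aromatic carbon para to a large group, leaves this read-out where it was. No measurement here offers an explanation for this lack of response.

The compounds shown leave open whether any substituent at this position can move the read-out beyond the scatter at the one concentration tested. An amine, a carboxylic acid or a longer chain such as butoxy at this place would test that, and the outcome cannot be told from bromo and methoxy alone.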